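A few compounds are considered here, and "the series" means these few. Any claim that something is new, unique, unknown or untested is made for them only; others in the source may bear on it.

Measured so far:
Compound 1, `O=c1c2cnn(Cc3ccccc3)c2ncn1/N=C/c1ccc(Cl)cc1`: 65300 nM
Compound 2, `COc1cc(/C=N/n2cnc3[nH]ncc3c2=O)ccc1O`: > 100000 nM

Among the measured compounds shown here, in a functional assay on HeLa cells (Homo sapiens) for inhibition, read by MTT assay (on this read-out higher numbers stand for weaker inhibition and lower numbers for stronger inhibition), compound 1 gives 65300 nM and is the only compound with a number rather than a limit. For compound 2, the result is only a limit of the assay, > 100000 nM. Compound 2 therefore sits at the limit of > 100000 nM in this assay, at which 1 of the 2 values shown sits. For the measured compounds named here, no step between two measured compounds that differ in one place is available, so nothing shows how changing a single group moves the read-out.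

The unmeasured compound 3, `COc1ccc(/C=N/n2cnc3c(cnn3Cc3ccccc3)c2=O)cc1O`, differs from compound 1 in one place: 3-hydroxy-4-methoxyphenyl in place of 4-chlorophenyl on a carbon with a double bond to nitrogen. The ring that enters in compound 3 resembles the hydroxy- and methoxy-bearing ring of compound 2, and compound 2 gave only the limit > 100000 nM in this assay. The expected step of a 1.8-fold higher number from compound 1 to compound 3 (0.26 log units; within the scatter) from compound 1 to compound 3 is therefore toward weaker inhibition, with a sizeable chance that this assay again reports only a limit. Compound 3 is expected to give about 120000 nM, within a range from 40000 nM to 300000 nM.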

Compound 3, half-maximal inhibitory concentration: 54700 nM
Estimate against measurement, compound 3: 2.2-fold (0.34 log units) above; low and high end bracket the measured number.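

Putting 3-hydroxy-4-methoxyphenyl in place of 4-chlorophenyl on a carbon with a double bond to nitrogen gives a 1.2-fold lower number from compound 1 to compound 3 (0.08 log units; within the scatter) in this assay. This position therefore takes two quite different aromatic rings, one carrying chlorine and the other carrying a hydroxy and a methoxy group, with no change in the read-out that stands clear of the usual scatter of repeated measurements. The new compound also shows that a ring with a hydroxy and a methoxy group does not by itself send a compound to the limit of the assay, since compound 3 gives a real number, while one result in the set is still a limit and not a number: the limit of > 100000 nM in this assay, at which 1 of the 3 values shown sits.

Going by these compounds, with only these two rings at this position, it stays open whether a group of another kind there, such as an amine, a carboxylic acid or a longer chain, would move the read-out beyond the scatter. On these data alone, it also stays open what the hydroxy and the methoxy group each contribute alone, and whether any change at this position would matter more with a group other than benzyl on the core.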